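A few compounds are considered here, and "the series" means these few. Any claim that something is new, unique, unknown or untested is made for them only; others in the source may bear on it.

Measured compounds:
compound 1, `COc1ccc(-c2cc(/C=C/C(=O)c3cc(OC)c(OC)c(OC)c3)[nH]n2)cc1OC` — 5680 nM
compound 2, `COc1ccc(C(=O)/C=C/c2cc(-c3cc(OC)c(OC)c(OC)c3)n[nH]2)cc1` — 6020 nM

In a functional assay on KM12 cells (Homo sapiens) for inhibition, read by sulforhodamine B assay, with a stated time of 48 h (on this read-out lower numbers stand for higher toxicity in this test and higher numbers for lower toxicity in this test), compound 1 gives 5680 nM, the lowest of the two numbers recorded so far. Compound 2 gives 6020 nM, which lies within the scatter of compound 1, so the two cannot be ordered on the present data.

Compound 3, `COc1cc(C(=O)/C=C/c2cc(-c3cc(OC)c(OC)c(OC)c3)n[nH]2)cc(OC)c1OC`, is not yet measured. It differs from compound 1 by methoxy in place of hydrogen on an aromatic carbon. Among the measured compounds shown here, both measured compounds carry the same shared core with methoxy-bearing aromatic rings at each end and sit close together, so there is no measured step on which to size this change. The expectation for compound 3 is a step from compound 1 of a 1.3-fold lower number from compound 1 to compound 3 (0.10 log units; within the scatter), that is, no change beyond the usual scatter in this assay, with a slight lean toward a lower number. Compound 3 is therefore estimated at 4500 nM, within a range of 1500 nM to 13000 nM.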

Compound 3, concentration lethal to 50% of the cells: 5770 nM
Beside the measured number, compound 3's estimate is 1.3-fold (0.11 log units) below it; the range from low to high includes it.
By their numbers in this assay, from the lowest: compounds 1, 3 and 2 (each within the scatter of the next).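

In this assay, methoxy in place of hydrogen on an aromatic carbon, ortho to a methoxy group and meta to a large group, gives a 1.0-fold higher number from compound 1 to compound 3 (0.01 log units; within the scatter), which lies within the scatter. Among the compounds shown here, this is the first sized step, and it shows that adding methoxy at this position leaves the number unchanged within the scatter, something the earlier pair, with no step between them, could not show. Nothing available here bears on the reason for this result.

One step with one group says little about the position in general: an amine, a carboxylic acid or a longer chain such as butoxy could behave differently here. On these data alone, whether methoxy in place of hydrogen gives a similar step elsewhere on the shared core also stays open.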